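The compounds below may be only part of what the source reports. "The series", "measured", "known", "first", "only" and "open" are said of these compounds alone.

Of the compounds shown here, three of the shared core have been measured in a functional assay on HL-60 cells (Homo sapiens) for cytotoxicity, read by MTT assay, with a stated time of 48 h; on this read-out lower numbers stand for stronger inhibition and higher numbers for weaker inhibition. Compound 1 `Nc1ccccc1Nc1n[n+]([O-])c2ccccc2[n+]1[O-]` gives 8300 nM in this assay; compound 2 `COc1ccc(Nc2n[n+]([O-])c3ccccc3[n+]2[O-])cc1` gives 900 nM in this assay; compound 3 `C=CCNc1n[n+]([O-])c2ccccc2[n+]1[O-]` gives 25800 nM in this assay. Compound 3 stands at the highest number of the three, with compound 1 nearer to it and compound 2 furthest away, and both gaps lie beyond the scatter of repeated measurements. Within the data shown here, no two of the measured compounds differ in just one place, so no single step between measured compounds can be read off.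

Compound 4 `CCNc1n[n+]([O-])c2ccccc2[n+]1[O-]` has not yet been measured in this assay. It differs from compound 3 as methyl in place of vinyl on a saturated chain carbon bound to a nitrogen on an aromatic ring; cut one bond further out, the change reads allyl to ethyl, allylamino to ethylamino. The chain keeps its attachment to the nitrogen on the aromatic ring and gives up only the double bond outside aromatic rings. Among the measured compounds shown here, the measured compounds offer no example of such a chain change, so the expectation rests on the closeness of the two structures.

The step expected here, a 1.2-fold higher number from compound 3 to compound 4 (0.07 log units; within the scatter), is small and not beyond the scatter, in either direction. Compound 4 is therefore estimated at 30000 nM in this assay, within a range from 12000 nM to 75000 nM.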

Compound 4, half-maximal inhibitory concentration: 9000 nM
For compound 4 the middle estimate is 3.3-fold (0.52 log units) above the measured one, and the stated range ends above it.
By their numbers in this assay, from the lowest: compound 2; then compounds 1 and 4 (each within the scatter of the next); then compound 3.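

In this assay the change of vinyl to methyl on a saturated chain carbon bound to a nitrogen on an aromatic ring, read one bond further out as allylamino to ethylamino, gives a 2.9-fold lower number from compound 3 to compound 4 (0.46 log units; beyond the scatter) as a modest step. Among these compounds, this is the first comparison between compounds that differ in one place, and it shows that the read-out responds to a small edit of this chain, one that takes away a single carbon and the double bond outside aromatic rings. No measurement in hand accounts for the direction or size of this step.

The single step changes the carbon count and the double bond together, so the compounds shown leave open which of the two goes with the lower number. A propyl chain would keep the carbon count of allyl without the double bond, while a methyl group, a butyl chain or a hydroxyethyl chain at the same nitrogen would show whether the trend from allyl to ethyl extends to other chains.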